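Estimating a Bromophenyl Analogue from Two Pyridyl Neighbours

This account rests on a few compounds, and the source may have more. Where it says the series, first, only, none or still open, it means among the compounds named here.

Of the compounds shown here, three have been measured in an ADME assay on THP-1 cells (Homo sapiens) for cytotoxicity, read by resazurin assay, with a stated time of 72 h; on this read-out higher numbers stand for lower toxicity in this test and lower numbers for higher toxicity in this test. Compound 1 `CC(C)=CCOc1ccc(C(=O)/C=C/c2cccnc2)c(O)c1` gives 100000 nM, compound 2 `COc1cc(OCC=C(C)C)ccc1C(=O)/C=C/c1ccncc1` gives 16000 nM, and compound 3 `COc1cc(OCC=C(C)C)ccc1C(=O)/C=C/c1cccnc1` gives 40000 nM. Compound 3 thus stands second highest of the three numbers, with both neighbours beyond the scatter: a 2.5-fold lower number from compound 1 to compound 3 (0.40 log units; beyond the scatter), and a 2.5-fold higher number from compound 2 to compound 3 (0.40 log units; beyond the scatter). Compound 4 `COc1cc(OCC=C(C)C)ccc1C(=O)/C=C/c1ccc(Br)cc1` differs from compound 3 by 4-bromophenyl in place of pyridin-3-yl on a double-bonded chain carbon bound to a double-bonded chain carbon. Within the data shown here, no measured step tests this exchange directly; the only step at the same place, the one from compound 2 to compound 3, was modest, and the other step was modest too, so only a modest step in this assay is expected here, most likely towards a lower number. Compound 4 is therefore expected to give 20000 nM, with a range from 5000 nM to 60000 nM, an expected step of a 2.0-fold lower number from compound 3 to compound 4 (0.30 log units; within the scatter).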

Compound 4, half-maximal cytotoxic concentration: 100000 nM
Beside the measured number, compound 4's estimate is 5.0-fold (0.70 log units) below it; the whole stated range lies below it.
By their numbers in this assay, from the lowest: compound 2; then compound 3; then compounds 1 and 4 (each within the scatter of the next).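

In this assay, at the place on a double-bonded chain carbon bound to a double-bonded chain carbon, 4-bromophenyl in place of pyridin-3-yl gives a 2.5-fold higher number from compound 3 to compound 4 (0.40 log units; beyond the scatter), and in place of pyridin-4-yl it gives a 6.3-fold higher number from compound 2 to compound 4 (0.80 log units; beyond the scatter). The earlier compounds had shown only an exchange between two pyridyl groups here, whereas this ring of carbon only moves the number upward, towards lower toxicity in this test, from both of them. No evidence on the cause of these steps is at hand. The compounds shown leave open whether the bromine or the loss of the ring nitrogen carries the steps. A plain phenyl or a 4-chlorophenyl group at this place would help to separate the two.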